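This account rests on a few compounds, and the source may have more. Where it says the series, first, only, none or still open, it means among the compounds named here.

Two pairs of compounds are compared here, each pair built on its own core. Compound 1 `O=C(/N=C(/NC(=O)c1cc(-c2ccccc2)nc2ccccc12)[Se]Cc1ccccc1)c1cc(-c2ccccc2)nc2ccccc12` carries a benzyl group where compound 2 `C[Se]/C(=N\C(=O)c1cc(-c2ccccc2)nc2ccccc12)NC(=O)c1cc(-c2ccccc2)nc2ccccc12` carries a methyl, the change being (hydrogen in place of phenyl on a saturated chain carbon bound to a selenium atom). Compound 3 `O=C(/N=C(/NC(=O)c1csc([N+](=O)[O-])c1)[Se]Cc1ccccc1)c1csc([N+](=O)[O-])c1` rests on a different core, and the difference between the two cores is not broken down here. Compound 4 `C[Se]/C(=N\C(=O)c1csc([N+](=O)[O-])c1)NC(=O)c1csc([N+](=O)[O-])c1` is the not yet measured partner of compound 3 and differs from it by hydrogen in place of phenyl on a saturated chain carbon bound to a selenium atom, the same change as between compound 1 and compound 2, at the same place.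

In a functional assay on MCF7 cells (Homo sapiens) for cytotoxicity, read by MTT assay, with a stated time of 72 h (on this read-out lower numbers stand for higher toxicity in this test and higher numbers for lower toxicity in this test), compound 1 gives 97000 nM. Compound 2 reaches a limit of this test, > 100000 nM, so no number is known for it. The change therefore made an at least 1.0-fold higher number from compound 1 to compound 2 (0.01 log units; that floor lies within the scatter), a floor that comes from compound 2 sitting at the limit of > 100000 nM in this assay, at which 1 of the 3 values shown sits. Compound 3 gives 83800 nM in this assay, close to compound 1.

For compound 4 the same change is expected to move the number little, a step of about a 1.3-fold higher number from compound 3 to compound 4 (0.12 log units; within the scatter), because the measured version of it gave an at least 1.0-fold higher number from compound 1 to compound 2 (0.01 log units; that floor lies within the scatter). The value of compound 4 in this assay is estimated at 110000 nM, with a likely range from 55000 nM to 250000 nM, and there is a fair chance that this test again reports only its limit.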

Compound 4, concentration lethal to 50% of the cells: > 100000 nM
Compound 4 gave a limit, no number; the forecaster's own chance of this, stated with the estimate: 55%; the middle value lies beyond the limit too.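

In this assay compound 4 gives > 100000 nM, which is a limit of the test and not a number. Replacing benzyl with methyl on the second core therefore gives only a floor for the step, an at least 1.1-fold higher number from compound 3 to compound 4 (0.07 log units; that floor lies within the scatter), and this floor says little about the true size of the change. Both cores end the same way, with the methyl compound at the limit, but this does not show that the change has the same size on both cores or how large it is on either: the same change on two cores in this assay, an at least 1.0-fold higher number (0.01 log units; that floor lies within the scatter) from compound 1 to compound 2 and an at least 1.1-fold higher number (0.07 log units; that floor lies within the scatter) from compound 3 to compound 4; the limit leaves it open whether they differ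

The compounds shown leave open what other groups would do on a saturated chain carbon bound to a selenium atom, such as a longer chain like butyl, or a chain ending in an amine or a carboxylic acid. It also remains open whether any such group would give a number far enough from the limit to allow a real comparison between cores, as the limit currently hides some of the results: the limit of > 100000 nM in this assay, at which 2 of the 4 values shown sit.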